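The source may hold more compounds than are shown below. What is called first, only, known or untested is meant among the compounds shown, and "the series" means these compounds.

Measured so far:
- compound 2 `Fc1ccccc1Cn1ccc2nc(-c3ccccc3)nc-2c1`: > 100000 nM
- compound 1 `Fc1cccc(F)c1-c1nc2ccn(Cc3ccccc3)cc-2n1`: > 100000 nM
- compound 3 `O=C(O)c1ccc(Cn2ccc3nc(-c4ccccc4)nc-3c2)cc1`: > 100000 nM

In an ADME assay on MDBK cells (Bos taurus) for cytotoxicity (a lower number here means that less compound is tolerated, a higher number that more compound is tolerated), compound 2 stands at the limit of > 100000 nM in this assay, at which 3 of the 3 values shown sit; this result is a limit of the assay and not a number. Compound 1 gives the same kind of limit. Compound 3 does too. No measured pair of these compounds differs in one place alone, so no measured step is available to guide the next change.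

Compound 4 `CCn1ccc2nc(-c3ccccc3)nc-2c1` has not yet been measured. It differs from compound 2 by methyl in place of 2-fluorophenyl on a saturated chain carbon bound to an aromatic nitrogen. With every measured value resting at the same limit, the step of a number no higher from compound 2 to compound 4 (the limit leaves the size open) is expected to be none beyond the scatter. Compound 4 is therefore estimated at 100000 nM, with a range from 50000 nM to 200000 nM.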

Compound 4, half-maximal cytotoxic concentration: > 100000 nM
Compound 4: a limit, no number; the forecaster's own chance of this, stated with the estimate: 80%; the middle value sits exactly at the limit.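

Compound 2 and compound 4 both end at a limit and not a number, so no step can be read between them. The compounds shown leave open what concentration would harm these cells, since all of them share one limit: the limit of > 100000 nM in this assay, at which 4 of the 4 values shown sit.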